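Enantiomer of a hydantoin-type EP3 antagonist

The compounds below may be only part of what the source reports. "The series", "measured", "known", "first", "only" and "open" are said of these compounds alone.

Of the compounds shown here, two have been measured in a functional assay on CHO cells for antagonist activity at prostaglandin E2 receptor EP3 subtype (Homo sapiens), read by FLIPR, with a stated time of 1 h; a lower number here means a stronger inhibitor, a higher number a weaker inhibitor. Compound 1, `Cc1cc(C2(C(C)C)OC(=O)NC2=O)c(=O)[nH]c1-c1ccc2ccccc2c1`, gives 6.31 nM in this assay. Compound 2, `CC(C)[C@]1(c2ccc(-c3ccc4ccccc4c3)[nH]c2=O)OC(=O)NC1=O`, gives 20 nM in this assay, the higher of the two numbers, and its gap to compound 1 lies beyond the scatter. The account now turns to compound 3, `CC(C)[C@@]1(c2ccc(-c3ccc4ccccc4c3)[nH]c2=O)OC(=O)NC1=O`, which has not yet been measured in this assay. Compound 3 differs from compound 2 as follows: the two compounds have the same atoms and bonds and differ only in configuration as drawn: 1 of 1 stereo elements differ; a stereocentre at a saturated ring carbon is drawn R in compound 2 and S in compound 3. Among the measured compounds shown here, no pair of measured compounds differing in a single stereocentre is available, so the size of the step cannot be read from a precedent. Compound 1 carries no drawn configuration, and its lower value beside compound 2 leaves room for the other configuration to be the stronger one. Compound 3 is therefore expected to give 4 nM, with a range from 1.5 nM to 12 nM, which would mean an estimated step of a 5.0-fold lower number from compound 2 to compound 3 (0.70 log units; beyond the scatter) toward a lower number.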

Compound 3, inhibition constant: 7.94 nM
Estimate against measurement, compound 3: 2.0-fold (0.30 log units) below; the measured number falls inside the stated range.
By their numbers in this assay, from the lowest: compounds 1 and 3 (each within the scatter of the next); then compound 2.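

Among the compounds shown here, this pair gives the first reading of what the configuration at the saturated ring carbon is worth in this assay, with a 2.5-fold lower number from compound 2 to compound 3 (0.40 log units; beyond the scatter). The S drawing therefore gives the lower number at this stereocentre, but the step is modest, and compound 2, drawn R, still gives 20 nM. The step can be assigned to this stereocentre alone, and to no other part of the structure, because of this: the fact that compounds 2 and 3 differ only in the configuration as drawn

Compound 1 carries no drawn configuration, so the compounds shown do not tell whether the same preference holds for its separate forms. They also leave open whether the S drawing would keep its edge if a longer chain or an amine stood in place of the isopropyl group on the stereocentre.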